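Changing one aryl arm: compound 3 to compound 4

A few compounds are considered here, and "the series" means these few. Any claim that something is new, unique, unknown or untested is made for them only; others in the source may bear on it.

Compound 3 `C=CCn1c(=O)/c(=C\c2ccccc2C(F)(F)F)[nH]c(=O)/c1=C\c1ccccc1OC` was tested in a functional assay on U-937 cells (Homo sapiens) for cytotoxicity, read by CCK-8 assay, with a stated time of 72 h (a higher number here means a weaker inhibitor, a lower number a stronger inhibitor), and gave 1500 nM. Among the numbers recorded so far, compound 3 has the lowest, but its nearest neighbour is compound 1 `C=CCn1c(=O)/c(=C\c2cccc(F)c2)[nH]c(=O)/c1=C\c1ccccc1OC`, which in this assay gives 2500 nM, and the step of a 1.7-fold lower number from compound 1 to compound 3 (0.22 log units; within the scatter) lies within the scatter, so the two cannot be ranked. Compound 2 `C=CCn1c(=O)/c(=C\c2ccc(Cl)c(Cl)c2)[nH]c(=O)/c1=C\c1ccccc1OC` is reported in this assay as "not active" (no number reported), with no number given.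

Compound 4 `C=CCn1c(=O)/c(=C\c2cc(F)ccc2C)[nH]c(=O)/c1=C\c1ccccc1OC` differs from compound 3 in one place: 5-fluoro-2-methylphenyl in place of 2-(trifluoromethyl)phenyl on a double-bonded chain carbon bound to an aromatic carbon. For the measured compounds named here, the only measured step at the same position is that from compound 1 to compound 3, which was within the scatter, so the record gives no sign that changing this aryl group moves the number much. Compound 2, however, shows that one such group can abolish measurable activity altogether, so a limit cannot be ruled out.

Compound 4 is therefore expected to stay close to compound 3, with a step of a 1.2-fold higher number from compound 3 to compound 4 (0.08 log units; within the scatter) that is not expected to exceed the scatter. The estimate for compound 4 in this assay is 1800 nM, with a range from 600 nM to 6000 nM.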

Compound 4, half-maximal inhibitory concentration: 1000 nM
Compound 4: the middle estimate sits 1.8-fold (0.26 log units) above what was measured; measured number inside the range.
By their numbers in this assay, from the lowest: compounds 4, 3 and 1 (each within the scatter of the next, the first and the last beyond it).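

In this assay the record now holds a step at this aryl arm that lies beyond the scatter, a 2.5-fold lower number from compound 1 to compound 4 (0.40 log units; beyond the scatter), and the change behind it is methyl in place of hydrogen on an aromatic carbon. The exchange of 2-(trifluoromethyl)phenyl, with its 10 heavy atoms, for 5-fluoro-2-methylphenyl, with its 8, gives a 1.5-fold lower number from compound 3 to compound 4 (0.18 log units; within the scatter), which does not rank the two compounds, so this position accepts both groups with no readable difference between them. Nothing measured here explains either step.

The methyl step rests on a single pair, so the compounds shown leave open whether methyl would act in the same way on another aryl arm, or whether a methoxy group, an amine or a carboxylic acid in its place would keep a number in this assay at all, since compound 2 is reported as "not active" (no number reported). They also leave open what a change would do at the other aryl arm or at the chain on the ring nitrogen, as both stay the same in all four compounds.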